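A thiazolyl group in place of 1,1-difluoroethyl

A few compounds are considered here, and "the series" means these few. Any claim that something is new, unique, unknown or untested is made for them only; others in the source may bear on it.

Compounds measured in an ADME assay on the whole organism (strain 129/SvEvBrd x C57BL/6) for metabolic stability, with Mus musculus as the target; on this read-out higher numbers stand for a longer-lived compound and lower numbers for a shorter-lived compound:
Compound 1 (`CC(O)c1nc([C@@H](O)[C@H](O)[C@H](O)CO)c[nH]1`) gives 4.4 h
Compound 2 (`CC(F)(F)c1nc([C@@H](O)[C@H](O)[C@H](O)CO)c[nH]1`) gives 1 h
Compound 3 (`OC[C@@H](O)[C@@H](O)[C@H](O)c1c[nH]c(C(F)(F)C(F)(F)F)n1`) gives 1.7 h

Compound 2 and compound 3 sit together at the low end of these numbers (a 1.7-fold higher number from compound 2 to compound 3 (0.23 log units; within the scatter)), while compound 1 stands clearly apart from compound 2 (a 4.4-fold lower number from compound 1 to compound 2 (0.64 log units; beyond the scatter)). The next compound, compound 4 (`OC[C@@H](O)[C@@H](O)[C@H](O)c1c[nH]c(-c2cscn2)n1`), carries 1,3-thiazol-4-yl in place of 1,1-difluoroethyl on an aromatic carbon. The core and its polyol chain stay the same.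

For the measured compounds named here, both measured steps touch this same carbon, so they are the only guide, and it is a limited one. Neither of them brings a ring to this place. Going by the values given here, the swap leading to compound 3 stayed within the scatter (a 1.7-fold higher number from compound 2 to compound 3 (0.23 log units; within the scatter)), whereas the larger step involved the hydroxyl-bearing group of compound 1 (a 4.4-fold lower number from compound 1 to compound 2 (0.64 log units; beyond the scatter)), which has no counterpart in the new group. Compound 4 is thus expected to stay close to compound 2, perhaps slightly higher, with no shift beyond the scatter in this assay as the likeliest outcome. For compound 4 the estimated step is a 1.5-fold higher number from compound 2 to compound 4 (0.18 log units; within the scatter) in this read-out. Compound 4 is estimated at 1.5 h with an expected range from 0.6 h to 3.5 h for its measurement.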

Compound 4, half-life: 4.2 h
For compound 4 the middle estimate is 2.8-fold (0.45 log units) below the measured one, outside the stated range (above it).
By their numbers in this assay, from the lowest: compounds 2 and 3 (each within the scatter of the next); then compounds 4 and 1 (each within the scatter of the next).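

In this assay, for the compounds shown here, this carbon between two ring nitrogen atoms now carries a ring for the first time, and the swap for 1,1-difluoroethyl gives a 4.2-fold higher number from compound 2 to compound 4 (0.62 log units; beyond the scatter), a shift that the earlier fluorinated groups had not produced. Going by these compounds alone, the hydroxyl-bearing group of compound 1 is also no longer the only group linked to the upper end of these numbers, since 1,3-thiazol-4-yl, which has no hydroxyl group, gives a 1.0-fold lower number from compound 1 to compound 4 (0.02 log units; within the scatter), leaving the two groups indistinguishable in this read-out despite their different atoms. No measurement is available that accounts for the gain over compound 2, so the result stands as an observation without an explanation.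

The compounds shown leave open whether any ring at this carbon would match compound 4, or whether the nitrogen and sulfur of 1,3-thiazol-4-yl are needed, a question that a ring made only of carbon atoms could address. They also leave open how an amine or a carboxylic acid at this same carbon would behave in this assay.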